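Replacing a Methoxybenzyl Arm with a Cyclopropyl Ketone Chain

The source may report more compounds than this note shows. Statements on the series, on what has been measured and on what is new or still open speak of the compounds shown alone.

Compound 2 `COc1ccc(CSc2nnc(-c3cc(OC)c(OC)c(OC)c3)n2-c2ccc(OC)cc2)cc1` gives 41100 nM in a functional assay on HepG2 cells (Homo sapiens) for inhibition, read by MTT assay, with a stated time of 48 h (a higher number here means a weaker inhibitor, a lower number a stronger inhibitor), the second highest of three numbers. Compound 1 `COc1ccc(-n2c(S)nnc2-c2cc(OC)c(OC)c(OC)c2)cc1` gives 57500 nM and compound 3 `COc1ccc(-n2c(SCc3ccc(F)cc3)nnc2-c2cc(OC)c(OC)c(OC)c2)cc1` gives 35000 nM; the step of a 1.4-fold lower number from compound 1 to compound 2 (0.15 log units; within the scatter) and the step of a 1.6-fold lower number from compound 1 to compound 3 (0.22 log units; within the scatter) stay within the scatter, as does a 1.2-fold lower number from compound 2 to compound 3 (0.07 log units; within the scatter). Compound 4 `COc1ccc(-n2c(SCC(=O)C3CC3)nnc2-c2cc(OC)c(OC)c(OC)c2)cc1` differs from compound 2 by cyclopropylcarbonyl in place of 4-methoxyphenyl on a saturated chain carbon bound to a sulfur. Among the measured compounds shown here, no measured step covers this change: the steps that put a benzyl group in place of hydrogen on a sulfur, or fluoro in place of methoxy, stayed within the scatter, so compound 4 is expected to land close to compound 2, with a 1.0-fold lower number from compound 2 to compound 4 (0.01 log units; within the scatter). The estimate for compound 4 is 40000 nM, between 15000 nM and 100000 nM.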

Compound 4, half-maximal inhibitory concentration: > 60000 nM
Compound 4 gave a limit, no number (the forecaster's own chance of this, stated with the estimate: 10%); middle value at least 1.5-fold (0.17 log units) from the limit.
By their numbers in this assay, from the lowest: compounds 3, 2 and 1 (each within the scatter of the next). At a limit, above all of these: compound 4.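

Compound 4 stands at a limit in this assay, not at a number: the limit of > 60000 nM in this assay, at which 1 of the 4 values shown sits. The steps read an at least 1.4-fold higher number from compound 2 to compound 4 (0.16 log units; that floor lies within the scatter), an at least 1.7-fold higher number from compound 3 to compound 4 (0.23 log units; that floor lies within the scatter) and an at least 1.0-fold higher number from compound 1 to compound 4 (0.01 log units; that floor lies within the scatter). Each is only a floor, so cyclopropylcarbonyl on the saturated chain carbon bound to a sulfur shows no gain over the earlier arms or over hydrogen on the sulfur, and the true size of these steps cannot be told. From the compounds shown here alone, it remains open whether an amine or a carboxylic acid on that carbon, or a longer chain there, would give a lower number.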